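Methoxy to hydroxymethyl on a phenylethynyl hydroxamate chain

This account rests on a few compounds, and the source may have more. Where it says the series, first, only, none or still open, it means among the compounds named here.

Measured compounds:
Compound 1, `CC(C)C(NC(=O)c1ccc(C#Cc2ccccc2)cc1)C(=O)NO`: > 3
Compound 2, `COCCNC(=O)C[C@H](NC(=O)c1ccc(C#Cc2ccccc2)cc1)C(=O)NO`: 2

In a physicochemical assay for lipophilicity (a higher number here means a more lipophilic compound, a lower number a more polar compound), compound 1 gives > 3, which is a limit of the assay rather than a number. Among the measured compounds shown here, compound 2 gives 2 in this assay and is the only compound with a number, since (the limit of > 3 in this assay, at which 1 of the 2 values shown sits).

Compound 3, `O=C(C[C@H](NC(=O)c1ccc(C#Cc2ccccc2)cc1)C(=O)NO)NCCCO`, differs from compound 2 only by hydroxymethyl in place of methoxy on a saturated chain carbon, two bonds along the chain from an amide-type nitrogen. Without a measured step of this kind, the expected step of a number 0.60 log units lower from compound 2 to compound 3 (beyond the scatter) is a moderate fall, beyond the scatter. Compound 3 is expected to give 1.4 in this assay, within 0.9 to 1.9.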

Compound 3, distribution coefficient: 2
Compound 3: middle estimate off by 0.60 log units, on the low side; measured number above the stated range.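

Placing hydroxymethyl, which carries a hydrogen-bond donor, in place of methoxy on a saturated chain carbon, two bonds along the chain from an amide-type nitrogen, gives no change at the digits printed from compound 2 to compound 3 (within the scatter) in this assay. At this position, then, going from 2-methoxyethyl to 3-hydroxypropyl leaves the reading where it stood, although this rests on a single pair. Nothing measured here gives a reason for that result. Going by these compounds, what an amine or a carboxylic acid at this chain end would give stays open. So does whether a longer chain ending in hydroxymethyl would read the same.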